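Swapping a 4-Chlorophenyl for a 3-Chlorophenyl at a Ring Nitrogen

This account rests on a few compounds, and the source may have more. Where it says the series, first, only, none or still open, it means among the compounds named here.

Compound 1 `Cc1nc(Nc2ccc(Cl)cc2)sc1C(=O)/C=C/c1ccccc1` carries a 4-chlorophenyl on a nitrogen on an aromatic ring. In a functional assay on Bel-7402 cells (Homo sapiens) for cytotoxicity, read by MTT assay (a higher number here means a weaker inhibitor, a lower number a stronger inhibitor), compound 1 gives > 25000 nM, which is a limit of the assay and not a number. Compound 3 `Cc1nc(Nc2cccc(Cl)c2)sc1C(=O)/C=C/c1ccccc1` differs from compound 1 by 3-chlorophenyl in place of 4-chlorophenyl on a nitrogen on an aromatic ring. In this assay compound 3 gives > 25000 nM, again a limit. Between them stands a step that the two limits leave unreadable from compound 1 to compound 3, so this pair says nothing about whether the move of the chlorine helps or harms.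

Compound 2 `COc1cc(/C=C/C(=O)c2sc(Nc3ccc(Cl)cc3)nc2C)cc(OC)c1OC` shares the same 4-chlorophenyl on a nitrogen on an aromatic ring; how its core differs from that of compound 1 is not broken down here. In this assay compound 2 gives > 25000 nM, once more a limit. Everything measured so far rests on (the limit of > 25000 nM in this assay, at which 3 of the 3 values shown sit).

Compound 4 `COc1cc(/C=C/C(=O)c2sc(Nc3cccc(Cl)c3)nc2C)cc(OC)c1OC` differs from compound 2 by 3-chlorophenyl in place of 4-chlorophenyl on a nitrogen on an aromatic ring. The place of the change is the same, word for word, as in the step from compound 1 to compound 3, so it is the same change repeated on the core of compound 2.

The step is expected to be a step that the limit leaves unreadable from compound 2 to compound 4, with compound 4 expected to sit at the limit just as its three relatives do. Compound 4 is therefore estimated at 30000 nM, with a range from 15000 nM to 80000 nM. That expectation rests on the limit of > 25000 nM in this assay, at which 3 of the 3 values shown sit, and on a step that the two limits leave unreadable from compound 1 to compound 3, which gives no hint of a gain large enough to bring a value below the limit.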

Compound 4, half-maximal inhibitory concentration: 14000 nM
Beside the measured number, compound 4's estimate is 2.1-fold (0.33 log units) above it; the whole stated range lies above it.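

In this assay the same exchange of 4-chlorophenyl for 3-chlorophenyl now gives an at least 1.7-fold lower number from compound 2 to compound 4 (0.25 log units; that floor lies within the scatter), so the change yields a readable number on this core, but the floor of the step does not by itself establish a gain. On the core of compound 1 the same 3-chlorophenyl, in compound 3, gives > 25000 nM in this assay, which is a limit of the assay and not a number, so the change does not bring a readable number on that core. The step on that core cannot be read, which leaves a single readable instance of the change and does not show that it runs the same way on both cores, with most of the series still resting on one ceiling: the limit of > 25000 nM in this assay, at which 3 of the 4 values shown sit.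

The compounds shown leave open whether a fluorophenyl, a methoxyphenyl or a plain phenyl on that nitrogen would behave as the 3-chlorophenyl does in compound 4. They also leave open whether a hydroxy group or an amine in place of the methoxy groups of compound 4 would keep a readable number in this assay.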